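A Bromophenyl Isomer of Compound 1 in the Same Assay

The source may hold more compounds than are shown below. What is called first, only, known or untested is meant among the compounds shown, and "the series" means these compounds.

Compound 1 `O=C(CCCCCCNC(=O)C(O)(O)C(F)(F)F)Nc1cccc(Br)c1` gives 3060 nM in a functional assay on HCT-116 cells (Homo sapiens) for inhibition, read by colorimetric assay, with a stated time of 3 days; a higher number here means a weaker inhibitor, a lower number a stronger inhibitor.
Compound 2 `CC(=O)C(=O)NCCCCCCC(=O)Nc1ccccc1` gives > 100000 nM in this assay, which is a limit of the assay and not a number.
Compound 3 `O=C(CCCCCCC(O)C(F)(F)F)Nc1ccccc1` gives > 40000 nM in this assay, again a limit rather than a number.

Going by the values given here, of the three measured compounds, compound 1 is thus the only one with a number to its name; the other two sit at limits, the limit of > 100000 nM in this assay, at which 1 of the 3 values shown sits, and (the limit of > 40000 nM in this assay, at which 1 of the 3 values shown sits). Among the compounds with values here, the single step between measured compounds that differ in one place, a step that the two limits leave unreadable from compound 2 to compound 3, is for that reason left unreadable, and it concerns the far end of the chain rather than the aromatic ring.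

Compound 4 `O=C(CCCCCCNC(=O)C(O)(O)C(F)(F)F)Nc1ccccc1Br` has not yet been measured. It differs from compound 1 by 2-bromophenyl in place of 3-bromophenyl on an amide-type nitrogen. Within the data shown here, no measured step touches this bromophenyl group, so the data give no direction and no size for the change; the one step that exists does not bear on it. The expectation for compound 4 rests on the value of compound 1 alone, and a step no larger than the usual scatter is expected, a 1.3-fold higher number from compound 1 to compound 4 (0.12 log units; within the scatter). Compound 4 is therefore estimated to give about 4000 nM, with a range from 1200 nM to 15000 nM, the width reflecting how little the measured steps say about this position.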

Compound 4, half-maximal inhibitory concentration: 14500 nM
The estimate for compound 4 lay 3.6-fold (0.56 log units) below the measured number, and the stated range covers the measured number.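

In this assay, going by these compounds alone, 2-bromophenyl in place of 3-bromophenyl on the amide-type nitrogen gives a 4.7-fold higher number from compound 1 to compound 4 (0.68 log units; beyond the scatter), the first readable step and the first to touch the aromatic end of the molecule. The two compounds have the same atoms and differ only in how the bromophenyl group is joined, so this step shows that the choice between these two isomeric groups is not neutral in this assay: of the pair, compound 4 is the weaker inhibitor, while still giving a number rather than a limit. Nothing measured here accounts for the size or direction of this step.

The compounds shown leave open whether a chlorophenyl or methoxyphenyl group on the same amide-type nitrogen would give a number closer to that of compound 1 or to that of compound 4. They also leave open whether the order seen between 3-bromophenyl and 2-bromophenyl would hold on a longer chain, or with a carboxylic acid at the far end of the chain.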